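From Bromo to Methylamino at the Assay Limit

The compounds below may be only part of what the source reports. "The series", "measured", "known", "first", "only" and "open" are said of these compounds alone.

Of the compounds shown here, three have been tested in an ADME assay on L1210/0 cells (Mus musculus) for cytotoxicity, with a stated time of 48 h (a higher number here means a weaker inhibitor, a lower number a stronger inhibitor), and none of them has yet given an exact number. Compound 1 (`Nc1ncnc2c1ncn2C[C@@H]1C[C@H](CO)c2ccccc21`) gives > 200000 nM, which is a limit of the assay. Compound 2 (`O=c1ccn(COCCO)c(=O)[nH]1`) gives > 200000 nM, which is also a limit. Compound 3 (`Nc1nc2c(nc(Br)n2COCCO)c(=O)[nH]1`) gives > 200000 nM, again a limit. The whole picture so far is the limit of > 200000 nM in this assay, at which 3 of the 3 values shown sit.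

Compound 4 (`CNc1nc2c(=O)[nH]c(N)nc2n1COCCO`) differs from compound 3 by having methylamino in place of bromo on an aromatic carbon. For the measured compounds named here, no measured pair shows what this swap does, so the expectation is for no step beyond the usual scatter in this assay, in either direction. That expectation rests on compound 3 with its limit of > 200000 nM. The expected change is an at least 1.3-fold lower number from compound 3 to compound 4 (0.12 log units; that floor lies within the scatter). Compound 4 is expected to give about 150000 nM, with an estimated range from 50000 nM to 300000 nM.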

Compound 4, half-maximal inhibitory concentration: > 200000 nM
Compound 4: only a limit was reported; the forecaster's own chance of this, stated with the estimate: 80%; middle value at least 1.3-fold (0.12 log units) from the limit.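

No step can be read from compound 3 to compound 4, because both results are limits rather than numbers: the limit of > 200000 nM in this assay, at which 4 of the 4 values shown sit.

The compounds shown leave open whether methylamino in place of bromo changes the result at all, and what exact value any of these compounds would give in this assay.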